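From phenyl to pyridin-2-yl on an amide-type nitrogen

The source may report more compounds than this note shows. Statements on the series, on what has been measured and on what is new or still open speak of the compounds shown alone.

- compound 1 `O=C(CCCCC(S)CCS)NO` gives 47.5%
- compound 2 `O=C(CCCCC(S)CCS)Nc1ccccc1` gives 7.67%
- compound 3 `O=C(CCCCC(S)CCS)Nc1ccccn1` is not yet measured

In a functional assay on Bel-7402 cells (Homo sapiens) for inhibition, read by MTT assay, with a stated time of 24 h, tested at 100 ug/mL (a lower number here means less inhibition of growth, a higher number more inhibition of growth at the concentration tested), compound 2 is the lower of the two measured compounds, well beyond the scatter. Compound 3 differs from it by pyridin-2-yl in place of phenyl on an amide-type nitrogen. Among the compounds with values here, the only measured step at this place, a number 39.8 percentage points lower from compound 1 to compound 2 (beyond the scatter), was large, but it replaced hydroxy, whereas here one six-membered aromatic ring replaces another, so only a small rise within the scatter is expected. For compound 3 the expected value is 14%, with an estimated range of 3% to 30%. The expected step is a number 6.3 percentage points higher from compound 2 to compound 3 (within the scatter).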

Compound 3, percent growth inhibition at one concentration: 3.62%
Compound 3: middle estimate off by 10.4 percentage points, on the high side, and the stated range covers the measured number.
By their numbers in this assay, from the lowest: compounds 3 and 2 (each within the scatter of the next); then compound 1.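

In this assay, exchanging one six-membered aromatic ring for another on the amide-type nitrogen gives a step within the scatter: a number 4.1 percentage points lower from compound 2 to compound 3 (within the scatter). The large step away from hydroxy also holds for pyridin-2-yl, a number 43.9 percentage points lower from compound 1 to compound 3 (beyond the scatter), so the low number seen with phenyl is not unique to that ring. Nothing at hand explains these numbers. From the compounds shown here alone, it remains open how a methoxy group or a plain amine on this nitrogen would compare with hydroxy. Also open, going by these compounds, is whether a longer chain in the shared core would change these steps.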